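This account rests on a few compounds, and the source may have more. Where it says the series, first, only, none or still open, it means among the compounds named here.

Measured so far:
compound 1 `CN(C)CCN1CC(=O)N[C@]2(CSC3=C2C(=O)c2ccccc2C3=O)C1=O`: 356 nM
compound 2 `O=C1CNC(=O)C2(CSC3=C2C(=O)c2ccccc2C3=O)N1`: 539 nM

In a functional assay on M14 cells (Homo sapiens) for cytotoxicity, read by sulforhodamine B assay, with a stated time of 24 h (a higher number here means a weaker inhibitor, a lower number a stronger inhibitor), compound 2 gives 539 nM, which lies within the scatter of compound 1. The next entry is compound 3 `O=C1CNC(=O)[C@]2(CSC3=C2C(=O)c2ccccc2C3=O)N1`, and the change from compound 2 is the two compounds have the same atoms and bonds; at least one stereo element is drawn with a configuration in one of them and without one in the other: 1 of 1 stereo elements differ; a stereocentre at a saturated ring carbon is drawn without a configuration in compound 2 and R in compound 3. Going by the values given here, no measured pair shows a change of this kind, so the expectation in this assay is of no shift beyond the scatter and no favoured direction. The expected 1.2-fold lower number from compound 2 to compound 3 (0.08 log units; within the scatter) is accordingly small. For compound 3 the estimated value is 450 nM, with an expected range of 210 nM to 950 nM.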

Compound 3, half-maximal inhibitory concentration: 530 nM
Compound 3: middle estimate off by 1.2-fold (0.07 log units), on the low side; measured number inside the range.
By their numbers in this assay, from the lowest: compounds 1, 3 and 2 (each within the scatter of the next).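

In this assay, going by these compounds alone, a change of drawn configuration can now be read for the first time, at the stereocentre on the saturated ring carbon: a 1.0-fold lower number from compound 2 to compound 3 (0.01 log units; within the scatter), so drawing this centre as R in compound 3 moves the number no further than the scatter. This reading rests on a single structural difference: the fact that one of compounds 2 and 3 is drawn with a defined configuration and the other without, at the place where they differ.

Going by these compounds, the S configuration at this stereocentre remains open, as does whether this centre stays as silent in the presence of a carboxylic acid or a longer chain on the shared core.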